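Working notes: bromo in place of pyridin-3-yl

The source may hold more compounds than are shown below. What is called first, only, known or untested is meant among the compounds shown, and "the series" means these compounds.

Compound 3 `O=C(NO)c1ccc(/C=C/c2ccnc(-c3cccnc3)c2)cc1` gives 14 nM in an assay on isolated protein for inhibition of protein deacetylase HDAC6 (Homo sapiens), read by fluorescence, with a stated time of 15 min (a lower number here means a stronger inhibitor, a higher number a weaker inhibitor), the lowest of the three numbers. Compound 2 `COc1ccccc1-c1cc(/C=C/c2ccc(C(=O)NO)cc2)ccn1` gives 28 nM in this assay, and the step of a 2.0-fold lower number from compound 2 to compound 3 (0.30 log units; within the scatter) lies within the scatter. Compound 1 `O=C(NO)c1cccc(/C=C/c2ccnc(-c3ccccc3O)c2)c1` gives 390 nM, well apart from compound 3. Compound 4 `O=C(NO)c1ccc(/C=C/c2ccnc(Br)c2)cc1` differs from compound 3 by bromo in place of pyridin-3-yl on an aromatic carbon. Going by the values given here, the only measured step at the same aromatic carbon is a 2.0-fold lower number from compound 2 to compound 3 (0.30 log units; within the scatter), a swap of one aromatic ring for another that stays within the scatter; no measured step removes the ring entirely, so its bearing is limited. Some weakening is expected, with wide uncertainty. Compound 4 is estimated at 60 nM (range 15 nM to 250 nM) in this assay, an expected step of a 4.3-fold higher number from compound 3 to compound 4 (0.63 log units; beyond the scatter).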

Compound 4, half-maximal inhibitory concentration: 320 nM
For compound 4 the middle estimate is 5.3-fold (0.73 log units) below the measured one, outside the stated range (above it).
By their numbers in this assay, from the lowest: compounds 3 and 2 (each within the scatter of the next); then compounds 4 and 1 (each within the scatter of the next).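

In this assay, bromo in place of either aromatic ring at this carbon gives a 23-fold higher number from compound 3 to compound 4 (1.36 log units; beyond the scatter) and an 11-fold higher number from compound 2 to compound 4 (1.06 log units; beyond the scatter) as large steps. The swap of one ring for another, a 2.0-fold lower number from compound 2 to compound 3 (0.30 log units; within the scatter) in size, showed no such change, so among these compounds having a ring at this carbon counts for more than which ring it is. Nothing measured here explains the loss on going to bromo.

Open, on these data alone, is whether a methyl, an amine or a morpholine at this carbon would stand nearer compound 3 or compound 4. Also open, as far as these compounds go, is whether a saturated ring such as cyclohexyl would hold the number of compound 3.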